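This account rests on a few compounds, and the source may have more. Where it says the series, first, only, none or still open, it means among the compounds named here.

Measured so far in a functional assay on A549 cells (Homo sapiens) for antiproliferative activity, read by MTT assay, with a stated time of 72 h; on this read-out lower numbers stand for stronger inhibition and higher numbers for weaker inhibition:
- compound 1 `COc1ncc(-c2ccc3c(c2)NC(=O)CO3)cc1NS(=O)(=O)c1ccc(F)cc1` gives 8070 nM
- compound 2 `COc1ncc(-c2ccc3c(c2)N(c2ccc(F)cc2)C(=O)CO3)cc1NS(=O)(=O)c1ccc(F)cc1` gives 6500 nM
- compound 3 `COc1ncc(-c2ccc3c(c2)N(c2ccccc2)C(=O)CO3)cc1NS(=O)(=O)c1ccc(F)cc1` gives 3490 nM

Of these three, compound 3 stands clearly apart only from compound 1, while compound 2 cannot be separated from it. Compound 4 `COc1ncc(-c2ccc3c(c2)N(C2CC2)C(=O)CO3)cc1NS(=O)(=O)c1ccc(F)cc1` has not been measured yet. It carries cyclopropyl in place of phenyl on an amide-type nitrogen in a ring, and cyclopropyl in place of phenyl on an amide-type nitrogen in a ring sums up the swap.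

Going by the values given here, three measured steps bear on this. Putting phenyl on that nitrogen gave a 2.3-fold lower number from compound 1 to compound 3 (0.36 log units; beyond the scatter) and is the only one of the three that clears the scatter. Putting 4-fluorophenyl there gave a 1.2-fold lower number from compound 1 to compound 2 (0.09 log units; within the scatter) and exchanging fluoro for hydrogen gave a 1.9-fold lower number from compound 2 to compound 3 (0.27 log units; within the scatter) on the same scale. Among the compounds with values here, no measured compound has a non-aromatic ring on this nitrogen, so the direction is uncertain. Since cyclopropyl is the smaller group, a result between compound 3 and compound 1 is expected, which means a small move towards a higher number in this assay that probably stays within the scatter. The estimated move is a 1.4-fold higher number from compound 3 to compound 4 (0.16 log units; within the scatter) and no more than that is expected. For compound 4 the expected value is 5000 nM and the estimated range runs from 2000 nM to 12000 nM on the same read-out.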

Compound 4, half-maximal inhibitory concentration: 3320 nM
Beside the measured number, compound 4's estimate is 1.5-fold (0.18 log units) above it; the measured number falls inside the stated range.
By their numbers in this assay, from the lowest: compounds 4, 3, 2 and 1 (each within the scatter of the next, the first and the last beyond it).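

In this assay, an aromatic ring on the amide-type nitrogen turns out not to be required: exchanging phenyl, with its 6 heavy atoms, for cyclopropyl, with 3 heavy atoms in a three-membered non-aromatic ring, gives a 1.1-fold lower number from compound 3 to compound 4 (0.02 log units; within the scatter), so the two groups cannot be told apart. Cyclopropyl in place of hydrogen gives a 2.4-fold lower number from compound 1 to compound 4 (0.39 log units; beyond the scatter), which clears the scatter as phenyl did, so two quite different ring groups now stand apart from the bare nitrogen, with 4-fluorophenyl as the exception, while cyclopropyl in place of 4-fluorophenyl gives a 2.0-fold lower number from compound 2 to compound 4 (0.29 log units; within the scatter), which stays inside the scatter. No measurement on hand explains why these groups match or what any of them does in the cell.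

Still open, as far as these compounds go, is whether a larger non-aromatic ring such as cyclohexyl, a plain chain such as ethyl, or a chain ending in an amine would hold the same level on this nitrogen. Also open, from the compounds shown here alone, is whether a single methyl would already match cyclopropyl, which would show how little carbon is enough at this position.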